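A thiazole amide follows a furan amide in the same series

The compounds below may be only part of what the source reports. "The series", "measured", "known", "first", "only" and "open" are said of these compounds alone.

Compound 1 `Nc1cccc2c(-c3cccc(NC(=O)c4cccc(C(F)(F)F)c4)c3)ccnc12` carries a 3-(trifluoromethyl)phenyl on the amide carbonyl, and in a functional assay on A375P cells (Homo sapiens) for antiproliferative activity, read by MTT assay, with a stated time of 48 h (a lower number here means a stronger inhibitor, a higher number a weaker inhibitor), compound 1 gives 7900 nM. Compound 2 `Cc1cc(C(=O)Nc2cccc(-c3ccnc4c(N)cccc34)c2)c(C)o1` has 2,5-dimethylfuran-3-yl in that place. In this assay compound 2 reaches only a limit, > 20000 nM, and no number is known for it; this is the limit of > 20000 nM in this assay, at which 1 of the 2 values shown sits. The change from the trifluoromethylphenyl to the dimethylfuranyl amide reads an at least 2.5-fold higher number from compound 1 to compound 2 (0.40 log units; beyond the scatter), so compound 2 stands as the weaker of the two measured compounds, though how much weaker is open.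

Compound 3 `Nc1cccc2c(-c3cccc(NC(=O)c4nccs4)c3)ccnc12` differs from compound 2 by 1,3-thiazol-2-yl in place of 2,5-dimethylfuran-3-yl on a carbonyl carbon. Among the measured compounds shown here, no measured step involves a 1,3-thiazol-2-yl group; the only step touching this carbonyl carbon, an at least 2.5-fold higher number from compound 1 to compound 2 (0.40 log units; beyond the scatter), shows that exchanging the ring there can move the number by at least a modest amount. With compound 2 already at the limit, the step of a number no higher from compound 2 to compound 3 (the limit leaves the size open) is expected to stay near the scatter. Compound 3 is therefore estimated at 20000 nM, within 6000 nM to 60000 nM, and a further limit read for compound 3 is thought likely.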

Compound 3, half-maximal inhibitory concentration: 16700 nM
The estimate for compound 3 lay 1.2-fold (0.08 log units) above the measured number, and the stated range covers the measured number.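

With 1,3-thiazol-2-yl on the carbonyl carbon, compound 3 gives a real number for a five-membered aromatic ring in this place in this assay, and replacing 3-(trifluoromethyl)phenyl with this ring reads a 2.1-fold higher number from compound 1 to compound 3 (0.33 log units; beyond the scatter) and so gives the earlier open-ended comparison a measured size. Between the two five-membered rings the reading is an at least 1.1-fold lower number from compound 2 to compound 3 (0.07 log units; that floor lies within the scatter) and does not separate them. Going by these compounds, the true gap between them stays unknown because compound 2 is held only at a limit: the limit of > 20000 nM in this assay, at which 1 of the 3 values shown sits.

On these data alone, it remains open whether a piperidine, or a chain ending in a carboxylic acid or an amine, on this carbonyl carbon would bring the number below that of compound 1. Whether a second substituted phenyl would do so is equally unsettled.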